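Working notes: the step from compound 1 to compound 4

The source may hold more compounds than are shown below. What is called first, only, known or untested is meant among the compounds shown, and "the series" means these compounds.

Measured in an ADME assay on HEK-293T cells (Homo sapiens) for cytotoxicity, read by MTT assay, with a stated time of 3 days; a higher number here means that more compound is tolerated, a lower number that less compound is tolerated:
- compound 1 `CCC(C)(C)NC(=O)COC(=O)c1ccc([N+](=O)[O-])o1`: > 100000 nM (a limit)
- compound 2 `CC(C)(NC(=O)COC(=O)c1ccc([N+](=O)[O-])o1)c1ccccc1`: > 100000 nM (a limit)
- compound 3 `CC(C)(C)N(Cc1cccc([N+](=O)[O-])c1)C(=O)COC(=O)c1ccc([N+](=O)[O-])o1`: 78000 nM

Compound 1 stands at > 100000 nM, which is a limit of the assay and not a number. Compound 2 also gives only a limit, > 100000 nM. The series is therefore dominated by the limit of > 100000 nM in this assay, at which 2 of the 3 values shown sit. Going by the values given here, compound 3 is the only measured compound with a number, 78000 nM.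

The unmeasured compound 4 `CC(C)(C)C(=O)COC(=O)c1ccc([N+](=O)[O-])o1` has tert-butyl in place of (1,1-dimethylpropyl)amino on a carbonyl carbon. Among the compounds with values here, no measured step changes the group at that place. Within the data shown here, the one step available is a step that the two limits leave unreadable from compound 1 to compound 2, with phenyl in place of ethyl, and it provides no size to carry over to this change.

The expectation therefore rests on the values of the neighbouring compounds, and it is a weak one. Among the measured compounds shown here, with compound 3 at 78000 nM as the only number, no step beyond the scatter is expected in this assay, and no direction can be named. The estimated step is an at least 1.1-fold lower number from compound 1 to compound 4 (0.04 log units; that floor lies within the scatter). The expected value for compound 4 is 90000 nM. The estimated range for compound 4 runs from 30000 nM to 200000 nM, and a reading reported only as a limit would not be surprising.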

Compound 4, half-maximal cytotoxic concentration: > 100000 nM
Compound 4 ended at the assay's limit (the forecaster's own chance of this, stated with the estimate: 55%); at least 1.1-fold (0.04 log units) between middle value and limit.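

In this assay compound 4 gives > 100000 nM as a limit and not a number. Compound 1 also gives only a limit, so no step can be read from compound 1 to compound 4. The compounds shown leave open whether tert-butyl in place of (1,1-dimethylpropyl)amino on a carbonyl carbon changes the tolerated concentration at all: the limit of > 100000 nM in this assay, at which 3 of the 4 values shown sit.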